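The compounds below may be only part of what the source reports. "The series", "measured", "known", "first", "only" and "open" are said of these compounds alone.

Measured so far:
Compound 1, `CC(C)(C)c1ccc(NC(=O)c2ccc(-c3ncccc3F)cc2)cc1`, gives 3 nM in a functional assay for antagonist activity at transient receptor potential cation channel subfamily V member 1 (Homo sapiens), read by FLIPR; on this read-out lower numbers stand for stronger inhibition and higher numbers for weaker inhibition.
Compound 2, `CCCNc1cccnc1-c1ccc(C(=O)Nc2ccc(C(C)(C)C)cc2)cc1`, gives 158 nM in this assay.
Compound 3, `CC(C)(C)c1ccc(NC(=O)c2ccc(-c3ncccc3-c3ncc[nH]3)cc2)cc1`, gives 3670 nM in this assay.

Compound 3 stands at the highest number of the three; its nearest neighbour is compound 2, and the gap to compound 1 is the widest in the set. The three compounds share one core and differ only in the group on the ring carbon two atoms from the ring nitrogen. Replacing fluoro by propylamino gave a 53-fold higher number from compound 1 to compound 2 (1.72 log units; beyond the scatter), replacing fluoro by the imidazolyl gave a 1200-fold higher number from compound 1 to compound 3 (3.09 log units; beyond the scatter), and going from propylamino to the imidazolyl gave a 23-fold higher number from compound 2 to compound 3 (1.37 log units; beyond the scatter).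

Compound 4, `Cc1nnc(-c2cccnc2-c2ccc(C(=O)Nc3ccc(C(C)(C)C)cc3)cc2)o1`, is not yet measured. It differs from compound 3 as follows: 5-methyl-1,3,4-oxadiazol-2-yl in place of 1H-imidazol-2-yl on an aromatic carbon. The measured steps show that every group tried at this place beyond fluoro raised the number, and that a second five-membered aromatic ring sat at the high end. For the measured compounds named here, no step between two such rings has been measured, so the change in this assay for compound 4 is estimated at a 1.8-fold lower number from compound 3 to compound 4 (0.26 log units; within the scatter), not beyond the scatter. Compound 4 is therefore expected to give about 2000 nM in this assay, within a range from 400 nM to 10000 nM.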

Compound 4, half-maximal inhibitory concentration: 387 nM
Estimate against measurement, compound 4: 5.2-fold (0.71 log units) above; the measured number lies below the stated range.
By their numbers in this assay, from the lowest: compound 1; then compound 2; then compound 4; then compound 3.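

In this assay, the exchange of 1H-imidazol-2-yl for 5-methyl-1,3,4-oxadiazol-2-yl gave a 9.5-fold lower number from compound 3 to compound 4 (0.98 log units; beyond the scatter), which shows that a second five-membered aromatic ring at this place, ortho to a large group, does not by itself fix the number at the high end. The two rings differ in more than one respect, with 1 hydrogen-bond donor and 1 hydrogen-bond acceptor on the ring that leaves against 0 donors and 3 acceptors on the ring that enters, so this single step cannot show which difference matters. The new ring still does not match the earlier groups, with a 2.4-fold higher number from compound 2 to compound 4 (0.39 log units; beyond the scatter) against propylamino and a 130-fold higher number from compound 1 to compound 4 (2.11 log units; beyond the scatter) against fluoro, so fluoro stays lowest of the four groups at this place.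

No measured property of these groups is available to account for these steps. As far as these compounds go, it remains open where a 1-methylimidazol-2-yl ring, a 1,3,4-oxadiazol-2-yl ring without its methyl or a chloro group would stand at this place, and the first two of these would help to separate the effect of the imidazole hydrogen from that of the methyl.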